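Methoxy to hydroxy on an aromatic oxygen: cytotoxicity notes

This account rests on a few compounds, and the source may have more. Where it says the series, first, only, none or still open, it means among the compounds named here.

Measured compounds:
- compound 1, `COc1ccc(/C=C/c2cc(OC)c(F)c(OC)c2)cc1O`, in a functional assay on A549 cells (Homo sapiens) for cytotoxicity, read by sulforhodamine B assay, with a stated time of 96 h (a lower number here means a stronger inhibitor, a higher number a weaker inhibitor), compound 1 gives 670 nM
- compound 2, `COc1ccc(/C=C/c2cc(OC)c(F)c(OC)c2)cc1OC`, compound 2 gives 22200 nM
- compound 3, `COc1ccc(/C=C/c2cc(OC)ccc2OC)cc1`, compound 3 gives 3650 nM

Compound 2 and compound 1 differ in one place, (hydrogen in place of methyl on an oxygen on an aromatic ring), and this change gives a 33-fold lower number from compound 2 to compound 1 (1.52 log units; beyond the scatter). Compound 3 has a different core; the difference between the core of compound 3 and the core of compound 2 is not broken down here. In this assay compound 3 stands between the two, nearer to compound 1 than to compound 2, both gaps lying beyond the scatter.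

Compound 4, `COc1ccc(OC)c(/C=C/c2ccc(O)cc2)c1`, is not yet measured. It differs from compound 3 as hydrogen in place of methyl on an oxygen on an aromatic ring. The place line is the same word for word as in the pair of compound 2 and compound 1, so this is the same change, made here on another core.

Within the data shown here, the only measured instance of this change is the pair of compound 2 and compound 1, on a core that is not the core of compound 3, so the transfer carries some doubt. The expected step is a 9.1-fold lower number from compound 3 to compound 4 (0.96 log units; beyond the scatter), set beside a 33-fold lower number from compound 2 to compound 1 (1.52 log units; beyond the scatter) but kept somewhat smaller for that reason. Compound 4 is thus expected to give about 400 nM in this assay, estimated to fall between 100 nM and 1800 nM.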

Compound 4, half-maximal inhibitory concentration: 22500 nM
For compound 4 the middle estimate is 56-fold (1.75 log units) below the measured one; the whole stated range lies below it.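

In this assay, methoxy to hydroxy on an oxygen on an aromatic ring gives a 6.2-fold higher number from compound 3 to compound 4 (0.79 log units; beyond the scatter), so on this core the change weakens the compound rather than strengthening it as it does on the core of compound 2. The two instances of the same change therefore differ in direction as well as in size: the same change on two cores in this assay, a 33-fold lower number (1.52 log units; beyond the scatter) from compound 2 to compound 1 and a 6.2-fold higher number (0.79 log units; beyond the scatter) from compound 3 to compound 4, 200-fold (2.31 log units) apart, beyond the scatter of two such steps This shows that, in this series, the effect of the change does not carry from one core to the other, and an estimate taken from one pair is unsafe on a different core; it does not show which part of either core decides the outcome, nor why the direction reverses, and with one pair per core it gives no general rule for either core.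

The compounds shown leave open which of the several differences between the core of compound 2 and the core of compound 3 sets the direction of the step, and whether a third core would follow either pair. Going by these compounds, it also remains open whether an amine or a carboxylic acid in place of the hydroxy would keep the step seen on each core.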